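Notes on the aryl urea terminus of the shared core

The compounds below may be only part of what the source reports. "The series", "measured", "known", "first", "only" and "open" are said of these compounds alone.

Compound 2 `O=C(NCCCCC(c1ccc(F)cc1)c1ccc(F)cc1)Nc1ccc(I)cc1` gives 11800 nM in a functional assay on MDA-MB-231 cells (Homo sapiens) for cytotoxicity, read by MTT assay, with a stated time of 48 h (on this read-out higher numbers stand for weaker inhibition and lower numbers for stronger inhibition), the highest of the three numbers in hand. Compound 1 `O=C(NCCCCC(c1ccc(F)cc1)c1ccc(F)cc1)Nc1ccc(Cl)cc1` gives 7680 nM, and the step of a 1.5-fold higher number from compound 1 to compound 2 (0.19 log units; within the scatter) sits within the scatter. Compound 3 `O=C(NCCCCC(c1ccc(F)cc1)c1ccc(F)cc1)Nc1ccc(Cl)c([N+](=O)[O-])c1` gives 4060 nM; the step of a 2.9-fold lower number from compound 2 to compound 3 (0.46 log units; beyond the scatter) is the only one beyond the scatter, while a 1.9-fold lower number from compound 1 to compound 3 (0.28 log units; within the scatter) is not. Compound 4 `Cc1ccc(NC(=O)NCCCCC(c2ccc(F)cc2)c2ccc(F)cc2)cc1C` differs from compound 2 in one place: 3,4-dimethylphenyl in place of 4-iodophenyl on an amide-type nitrogen. For the measured compounds named here, no measured step trades a halogen for a hydrocarbon group, so only the halogen swap a 1.5-fold higher number from compound 1 to compound 2 (0.19 log units; within the scatter) and the aryl swap a 2.9-fold lower number from compound 2 to compound 3 (0.46 log units; beyond the scatter) bear on it, both small. Compound 4 is therefore expected to give 8500 nM (range 3000 nM to 25000 nM), a step of a 1.4-fold lower number from compound 2 to compound 4 (0.14 log units; within the scatter) expected to stay within the scatter.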

Compound 4, half-maximal inhibitory concentration: > 20000 nM
Compound 4: only a limit was reported (the forecaster's own chance of this, stated with the estimate: 10%); middle value at least 2.3-fold (0.37 log units) from the limit.
By their numbers in this assay, from the lowest: compounds 3, 1 and 2 (each within the scatter of the next, the first and the last beyond it). At a limit, above all of these: compound 4.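

Compound 4 is reported only as a limit: the limit of > 20000 nM in this assay, at which 1 of the 4 values shown sits. The step of an at least 4.9-fold higher number from compound 3 to compound 4 (0.69 log units; beyond the scatter) and the step of an at least 2.6-fold higher number from compound 1 to compound 4 (0.41 log units; beyond the scatter) clear the scatter even at their floors, whereas the step of an at least 1.6-fold higher number from compound 2 to compound 4 (0.22 log units; that floor lies within the scatter) has a floor that does not. On the amide-type nitrogen, 3,4-dimethylphenyl, which carries carbon only, thus gives no number matching compound 1 or compound 3, while its distance from compound 2 stays unresolved.

From the compounds shown here alone, whether a single methyl, a methoxy or a trifluoromethyl group on the phenyl ring would track with 3,4-dimethylphenyl remains open. Going by these compounds, the true value of compound 4 also remains open.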